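Cyclohexyl amides at the assay limit: ring fluorination

A few compounds are considered here, and "the series" means these few. Any claim that something is new, unique, unknown or untested is made for them only; others in the source may bear on it.

Measured compounds:
compound 1 `O=C(C1CCCCC1)N1CC(c2nc(-c3cccc(F)c3)no2)C1`: a limit of the assay, > 10000 nM
compound 2 `O=S(=O)(c1ccc(Cl)cc1)N1CC(c2nc(-c3cccc(Cl)c3)no2)C1`: 170 nM
compound 3 `O=C(C1CCC(C(F)(F)F)CC1)N1CC(c2nc(-c3cccc(F)c3)no2)C1`: a limit of the assay, > 10000 nM

In an assay on HEK293 cells for negative allosteric modulation of metabotropic glutamate receptor 5 (Homo sapiens), read by FLIPR (on this read-out higher numbers stand for weaker inhibition and lower numbers for stronger inhibition), compound 1 sits only at a limit, with no number beneath it. Compound 3 likewise sits at a limit. Within the data shown here, compound 2 is the one measured compound with a number; it differs from compound 1 in more than one place, so its value can only be set beside that of compound 1 without reading a step.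

Among the measured compounds shown here, the single one-place step among the measured compounds, a step that the two limits leave unreadable from compound 1 to compound 3, cannot be sized, because the limit of > 10000 nM in this assay, at which 2 of the 3 values shown sit, holds both ends of it.

Compound 4 `O=C(C1CCC(F)(F)CC1)N1CC(c2nc(-c3cccc(F)c3)no2)C1` is the next amide. Its change from compound 1: 4,4-difluorocyclohexyl in place of cyclohexyl on a carbonyl carbon. For the measured compounds named here, the only related step, from compound 1 to compound 3, also adds fluorinated substitution to the saturated ring and left the limit untouched. The step from compound 1 to compound 4 is therefore expected to show no movement beyond the scatter, most likely staying at the limit: a step that the limit leaves unreadable from compound 1 to compound 4. Compound 4 is estimated at 15000 nM in this assay, within 5000 nM to 50000 nM, with a limit the likeliest outcome.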

Compound 4, half-maximal inhibitory concentration: > 10000 nM
Compound 4: a limit, no number (the forecaster's own chance of this, stated with the estimate: 85%); the middle value is on the limit's open side.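

In this assay compound 4 gives > 10000 nM, a limit of the assay, as compound 1 also does, so no step between these two compounds can be read: the limit of > 10000 nM in this assay, at which 3 of the 4 values shown sit.

Left open is how far these amides lie beyond the limit. Also left open is which of the places separating compound 2, at 170 nM, from compound 1 carries its measurable value.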